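The source may report more compounds than this note shows. Statements on the series, on what has been measured and on what is new or still open speak of the compounds shown alone.

Measured so far in a functional assay on PC-3 cells (Homo sapiens) for inhibition; a higher number here means a weaker inhibitor, a lower number a stronger inhibitor:
compound 1, `COc1ccc(C(=O)N2CCN(c3nc(N)c4cc(OC)c(OC)cc4n3)CC2)cc1OC`, 71000 nM;
compound 2, `COc1cc2nc(N3CCN(C(=O)c4cccc5ccccc45)CC3)nc(N)c2cc1OC`, 59000 nM;
compound 3, `COc1cc2nc(N3CCN(S(=O)(=O)c4ccc([N+](=O)[O-])cc4)CC3)nc(N)c2cc1OC`, 36000 nM.

Compound 3 carries the lowest of the three numbers, yet its gaps to compound 2 and to compound 1 both lie within the scatter, so no ranking among the three is read from them. Among the compounds with values here, the only single-change step measured, a 1.2-fold lower number from compound 1 to compound 2 (0.08 log units; within the scatter), concerns an aryl group on a carbonyl carbon and stayed within the scatter. Compound 4, `COc1cc2nc(N3CCN(S(=O)(=O)c4cc(Cl)ccc4Cl)CC3)nc(N)c2cc1OC`, is compound 3 with 2,5-dichlorophenyl in place of 4-nitrophenyl on a sulfonyl sulfur. Within the data shown here, no measured step exchanges an aryl group on a sulfonyl sulfur, so the step from compound 1 to compound 2 bears on this change only loosely; from it, no step beyond the scatter in this assay is expected, no change at the digits printed from compound 3 to compound 4 (within the scatter). Compound 4 is therefore expected to give about 36000 nM, within a range of 12000 nM to 110000 nM.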

Compound 4, half-maximal inhibitory concentration: 60000 nM
Compound 4: middle estimate off by 1.7-fold (0.22 log units), on the low side, and the stated range covers the measured number.
By their numbers in this assay, from the lowest: compounds 3, 2, 4 and 1 (each within the scatter of the next).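

In this assay, within the data shown here, the only step measured on a sulfonyl sulfur reads a 1.7-fold higher number from compound 3 to compound 4 (0.22 log units; within the scatter) and gives no ranking of 4-nitrophenyl against 2,5-dichlorophenyl. Like the step on the carbonyl carbon, it stays within the scatter, so the sulfonyl place now also has a single-change comparison. Nothing available bears on this result.

Still open, from the compounds shown here alone, is whether any group on the sulfonyl sulfur gives a step beyond the scatter. Candidates include a methyl group or longer alkyl chain in place of the aryl ring, or a phenyl ring carrying an amine or a carboxylic acid.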